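The source may report more compounds than this note shows. Statements on the series, on what has been measured and on what is new or still open speak of the compounds shown alone.

Of the compounds shown here, two share a core and have been tested in an assay on isolated protein for inhibition of NT-3 growth factor receptor (Homo sapiens); a higher number here means a weaker inhibitor, a lower number a stronger inhibitor. Compound 1, `Cn1cc(/C=C2\C(=O)Nc3ccc(S(N)(=O)=O)cc32)c2ccccc21`, carries a primary sulfonamide on one ring and no substituent on the oxygen-bearing side; in this assay compound 1 gives 6.86 nM. Compound 2, `CN(C)S(=O)(=O)c1ccc2c(c1)/C(=C/c1cn(C)c3ccc(O)cc13)C(=O)N2`, carries a dimethylated sulfonamide together with a hydroxy group on the other aromatic ring; in this assay compound 2 gives 9.72 nM. These two numbers lie within the usual scatter of repeated measurements of each other, so on the numbers shown compound 2 stands level with compound 1, and no order between them can be read from the data.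

The next compound, compound 3, `COc1ccc2c(c1)c(/C=C1\C(=O)Nc3ccc(S(=O)(=O)N(C)C)cc31)cn2C`, differs from compound 2 in a single place: methyl in place of hydrogen on an oxygen on an aromatic ring, which, read one bond further out, is hydroxy to methoxy. Among the compounds with values here, no measured pair shows this particular change, so there is no directly comparable step to lean on. On that basis only a small step is expected in this assay, if any, with a slight lean toward a higher number. The step from compound 2 to compound 3 is expected to be a 1.5-fold higher number from compound 2 to compound 3 (0.19 log units; within the scatter), and compound 3 is estimated at 15 nM, within a range from 5 nM to 45 nM.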

Compound 3, half-maximal inhibitory concentration: 11.7 nM
Beside the measured number, compound 3's estimate is 1.3-fold (0.11 log units) above it; the range from low to high includes it.
By their numbers in this assay, from the lowest: compounds 1, 2 and 3 (each within the scatter of the next).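

In this assay, methyl in place of hydrogen on an oxygen on an aromatic ring, which is hydroxy to methoxy, gives a 1.2-fold higher number from compound 2 to compound 3 (0.08 log units; within the scatter). Within the data shown here, this is the first pair here that differs in only one place, so it gives the first direct reading of a single change, and it shows that the hydrogen on this oxygen can be replaced by a methyl with the two compounds standing level. Nothing measured here accounts for this result or says what the oxygen contributes to inhibition.

The compounds shown place only hydroxy and methoxy at this oxygen, so it remains open whether the numbers would stay level with a longer chain there, such as ethyl or propyl, or with a chain ending in an amine or a carboxylic acid. This change is also seen only alongside the dimethylated sulfonamide, so whether hydroxy and methoxy would stand level alongside the primary sulfonamide of compound 1 remains unanswered.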